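Ethyl to Methylsulfonyl: an Estimate Before the Measurement

This account rests on a few compounds, and the source may have more. Where it says the series, first, only, none or still open, it means among the compounds named here.

Compound 1, `O=c1c(-c2nn[nH]n2)c[nH]c2c(Cl)c(Cl)ccc12`: > 10 mg/kg
Compound 2, `O=C(O)c1cnc2ccc(C(F)(F)F)cc2c1`: > 50 mg/kg
Compound 3, `CCc1cccc2c(=O)c(-c3nn[nH]n3)c[nH]c12`: > 25 mg/kg

For the measured compounds named here, in a functional assay on the whole organism (strain Sprague-Dawley) for inhibition, with Rattus norvegicus as the target (a higher number here means that more compound is needed for the effect, a lower number that less compound is needed), every number so far is a limit rather than a measured value. Compound 1 sits at the limit (the limit of > 10 mg/kg in this assay, at which 1 of the 3 values shown sits). Compound 2 sits at the limit (the limit of > 50 mg/kg in this assay, at which 1 of the 3 values shown sits). Going by the values given here, compound 3 sits at the limit (the limit of > 25 mg/kg in this assay, at which 1 of the 3 values shown sits), so its true value is unknown and no step between measured compounds can be drawn.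

Compound 4, `CS(=O)(=O)c1cccc2c(=O)c(-c3nn[nH]n3)c[nH]c12`, differs from compound 3 by methylsulfonyl in place of ethyl on an aromatic carbon. With only limits to go on, the expected step is a step that the limit leaves unreadable from compound 3 to compound 4, meaning no change beyond the scatter in either direction. Compound 4 is therefore expected at 30 mg/kg, within a range from 10 mg/kg to 100 mg/kg, and most likely another limit.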

Compound 4, minimum effective dose: > 25 mg/kg
Compound 4: a limit, no number; the forecaster's own chance of this, stated with the estimate: 75%; the middle value lies beyond the limit too.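

Compound 3 and compound 4 both stop at the same limit, so no step between them can be read: the limit of > 25 mg/kg in this assay, at which 2 of the 4 values shown sit.

The compounds shown leave open what dose of any of them gives the effect, and whether methylsulfonyl in place of ethyl changes that dose.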